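Chloro to Methyl and Cell Tolerance in Two Cores

The compounds below may be only part of what the source reports. "The series", "measured", "known", "first", "only" and "open" are said of these compounds alone.

Compound 1 `Cc1cc(Oc2ccccc2OCCn2ccc(=O)[nH]c2=O)c(Cl)c2cc(C#N)ccc12`: > 100000 nM
Compound 2 `Cc1cc(Oc2ccccc2OCCn2ccc(=O)[nH]c2=O)c(C)c2cc(C#N)ccc12`: > 100000 nM
Compound 3 `Cc1c(Oc2ccc(F)cc2OCCn2ccc(=O)[nH]c2=O)cc(Cl)c2ccc(C#N)cc12`: 82000 nM

Three compounds were measured in a toxicity assay on MT2 cells (Homo sapiens) for cytotoxicity, read by MTT assay; a higher number here means that more compound is tolerated, a lower number that less compound is tolerated. For compound 1 the value > 100000 nM is a limit of the assay, not a number. For compound 2 the value > 100000 nM is likewise a limit. Within the data shown here, compound 3 gives the only number, 82000 nM. The change methyl in place of chloro on an aromatic carbon gave a step that the two limits leave unreadable from compound 1 to compound 2, because the limit of > 100000 nM in this assay, at which 2 of the 3 values shown sit, hides its size. Compound 4 `Cc1cc(Oc2ccc(F)cc2OCCn2ccc(=O)[nH]c2=O)c(C)c2cc(C#N)ccc12` carries the same kind of change on the core of compound 3, (methyl in place of chloro on an aromatic carbon), though here the place is meta to a large group where in compound 1 it was ortho to a large group. How the core of compound 3 differs from that of compound 1 is not broken down here. For compound 4 the expected step is a 1.2-fold higher number from compound 3 to compound 4 (0.06 log units; within the scatter), resting on compound 3 with 82000 nM. The estimate for compound 4 in this assay is 95000 nM.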

Compound 4, half-maximal cytotoxic concentration: > 100000 nM
Compound 4: a limit, no number (the forecaster's own chance of this, stated with the estimate: 60%); at least 1.0-fold (0.02 log units) between middle value and limit.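

In this assay, methyl in place of chloro on the core of compound 3 gives an at least 1.2-fold higher number from compound 3 to compound 4 (0.08 log units; that floor lies within the scatter). Compound 4 sits at a limit, not a number, so this step is only a floor, and it does not show that the change raises tolerance on this core. The steps from compound 1 to compound 2 and from compound 2 to compound 4 cannot be read, so the size of the change on the two cores cannot be compared, because of a limit: the limit of > 100000 nM in this assay, at which 3 of the 4 values shown sit.

From the compounds shown here alone, it remains open how an amine or a carboxylic acid on that aromatic carbon would read in this assay. Going by these compounds, a longer chain there is equally open.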